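Swapping Dimethylamino for Methoxy on a Benzyl Arm

The source may report more compounds than this note shows. Statements on the series, on what has been measured and on what is new or still open speak of the compounds shown alone.

Compound 1 `CCN(CCCCOc1ccc(/C=C/C(=O)c2ccc(N(C)C)cc2O)cc1)Cc1ccccc1N(C)C` gives 4300 nM in an assay on isolated protein for inhibition of Amine oxidase [flavin-containing] B (Homo sapiens); a higher number here means a weaker inhibitor, a lower number a stronger inhibitor. Compound 2 `CCN(CC)CCCOc1ccc(C(=O)/C=C/c2ccc(N(C)C)cc2)c(O)c1` gives 4100 nM, and compound 3 `CCN(CCCOc1ccc(C(=O)/C=C/c2ccc(N(C)C)cc2)c(O)c1)Cc1ccccc1N(C)C` gives 3200 nM; all three numbers lie within the usual scatter of one another, so compound 1 stands level with the other two rather than apart from them. Compound 4 `CCN(CCCCOc1ccc(/C=C/C(=O)c2ccc(N(C)C)cc2O)cc1)Cc1ccccc1OC` differs from compound 1 by methoxy in place of dimethylamino on an aromatic carbon. Among the measured compounds shown here, the one measured step that touches this arm, a 1.3-fold lower number from compound 2 to compound 3 (0.11 log units; within the scatter), shows that bringing in the whole 2-(dimethylamino)phenyl group changed nothing beyond the scatter, which suggests this arm has little bearing on the number. A step no larger than the scatter is therefore expected, in no particular direction. Compound 4 is expected to give 4300 nM, within 2000 nM to 9500 nM. That expectation amounts to no change at the digits printed from compound 1 to compound 4 (within the scatter).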

Compound 4, half-maximal inhibitory concentration: 4600 nM
Estimate against measurement, compound 4: 1.1-fold (0.03 log units) below; the range from low to high includes it.
By their numbers in this assay, from the lowest: compounds 3, 2, 1 and 4 (each within the scatter of the next).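

In this assay, replacing the dimethylamino group with methoxy gives a 1.1-fold higher number from compound 1 to compound 4 (0.03 log units; within the scatter), so this assay does not tell the two groups apart at this aromatic carbon. The earlier step exchanged the whole 2-(dimethylamino)phenyl group for methyl, whereas this one alters only the group on the ring, and it too stays within the scatter. No supporting evidence bears on this result. A carboxylic acid or a primary amine at this aromatic carbon could still shift the number beyond the scatter. Going by these compounds, whether a bare hydrogen there would do so also remains open.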